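Swapping a Benzyl for an Aryl on the Lactam Nitrogen

A few compounds are considered here, and "the series" means these few. Any claim that something is new, unique, unknown or untested is made for them only; others in the source may bear on it.

Compound 1, `O=C1CC(c2nc(-c3cccc(Cl)c3)no2)CN1c1ccc(Cl)cc1`, in an in vitro functional assay on HEK293-A cells for negative allosteric modulation of metabotropic glutamate receptor 5 (Homo sapiens), read by FLIPR and calcium flux (a lower number here means a stronger inhibitor, a higher number a weaker inhibitor), gives > 10000 nM, which is a limit of the assay.
Compound 2, `O=C1CC(c2nc(-c3cccc(Cl)c3)no2)CN1Cc1ccc(F)cc1`, gives 3600 nM in this assay.
Compound 3, `CC(C)CN1CC(c2nc(-c3cccc(Cl)c3)no2)CC1=O`, gives 920 nM in this assay.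

Compound 2 has the highest of the two numbers shown; its nearest neighbour is compound 3, with a 3.9-fold lower number from compound 2 to compound 3 (0.59 log units; beyond the scatter). The step to compound 4, `Cc1ccccc1N1CC(c2nc(-c3cccc(Cl)c3)no2)CC1=O`, is 2-methylphenyl in place of 4-fluorobenzyl on an amide-type nitrogen in a ring. This reverses the kind of change seen in an at least 2.7-fold lower number from compound 1 to compound 2 (0.44 log units; beyond the scatter), where replacing an aromatic ring bound directly to the ring nitrogen by a benzyl gave a lower number. Run backwards, that points to a higher number for compound 4, although the size is uncertain because compound 1 sits at the limit of > 10000 nM in this assay, at which 1 of the 3 values shown sits. Compound 4 is therefore expected to give about 9000 nM, between 3000 nM and 30000 nM, an expected 2.5-fold higher number from compound 2 to compound 4 (0.40 log units; beyond the scatter).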

Compound 4, half-maximal inhibitory concentration: 370 nM
Estimate against measurement, compound 4: 24-fold (1.39 log units) above; measured number below the stated range.
By their numbers in this assay, from the lowest: compound 4; then compound 3; then compound 2. At a limit, above all of these: compound 1.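

Compound 4 shows that an aromatic ring bound directly to the amide-type nitrogen does not by itself give a weak inhibitor: 2-methylphenyl in place of 4-fluorobenzyl gives a 9.7-fold lower number from compound 2 to compound 4 (0.99 log units; beyond the scatter), and in place of isobutyl it gives a 2.5-fold lower number from compound 3 to compound 4 (0.40 log units; beyond the scatter). Among directly bound rings the substitution matters, with 2-methylphenyl in place of 4-chlorophenyl giving an at least 27-fold lower number from compound 1 to compound 4 (1.43 log units; beyond the scatter). Compound 1 stands at a limit, not at a number: the limit of > 10000 nM in this assay, at which 1 of the 4 values shown sits.

Still open, from the compounds shown here alone, is whether the methyl group or its place on the ring accounts for this step. Going by these compounds, how a plain phenyl ring or a longer alkyl chain on this nitrogen would compare also remains unknown.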